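The compounds below may be only part of what the source reports. "The series", "measured", "known", "first", "only" and "open" are said of these compounds alone.

Measured compounds:
Compound 1 `CC(CCc1ccc(OCc2ccc3ccccc3n2)cc1)Cc1nnn[nH]1`: 25 nM
Compound 2 `CC(CCCc1nnn[nH]1)c1ccc(OCc2ccc3ccccc3n2)cc1`: 43 nM
Compound 3 `O=C(O)CCC(Cc1cccc(OCc2ccc3ccccc3n2)c1)c1ccccc1`: 52 nM

In an assay on membranes from lung (Cavia porcellus) for binding affinity to cysteinyl leukotriene receptor (Homo sapiens) (a higher number here means a weaker inhibitor, a lower number a stronger inhibitor), compound 1 gives the lowest of the three numbers. Compound 2 sits within the scatter of compound 1, so the two cannot be ordered. Compound 3 lies beyond the scatter, so compound 1 gives the lower number of that pair. Compound 4 `O=C(O)CCCCc1ccc(OCc2ccc3ccccc3n2)cc1` is not yet measured in this assay. It differs from compound 1 as follows: 2-carboxyethyl in place of 1-((1H-tetrazol-5-yl)methyl)ethyl on a saturated chain carbon, two bonds along the chain from an aromatic carbon. Within the data shown here, no measured pair shows this change, so its size is open. Compound 3, which carries a carboxylic acid, gives 52 nM in this assay. Compound 4 is expected to give about 80 nM in this assay, with a range from 25 nM to 300 nM. The expected step of a 3.2-fold higher number from compound 1 to compound 4 (0.51 log units; beyond the scatter) is a modest rise, near the edge of the scatter.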

Compound 4, inhibition constant: 110 nM
For compound 4 the middle estimate is 1.4-fold (0.14 log units) below the measured one, within the range that was stated.
By their numbers in this assay, from the lowest: compounds 1, 2 and 3 (each within the scatter of the next, the first and the last beyond it); then compound 4.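

In this assay the change from 1-((1H-tetrazol-5-yl)methyl)ethyl to 2-carboxyethyl gives a 4.4-fold higher number from compound 1 to compound 4 (0.64 log units; beyond the scatter) and so provides the first step read at this position. A carboxylic acid on the unbranched chain is tolerated here with a modest loss, and compound 1 keeps the lower number. No supporting data bear on the origin of this step.

The change swaps the tetrazole for the acid and also removes the methyl branch, and the compounds shown do not separate these two differences. A methyl-branched carboxylic acid chain or an unbranched tetrazole chain would be needed to tell them apart.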